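This account rests on a few compounds, and the source may have more. Where it says the series, first, only, none or still open, it means among the compounds named here.

Measured so far in a functional assay on Jurkat E6.1 cells (Homo sapiens) for cytotoxicity, read by MTT assay, with a stated time of 24 h; a higher number here means a weaker inhibitor, a lower number a stronger inhibitor:
compound 1 `COC(=O)/C(=C\c1ccc(OC(=O)c2ccc(OC)cc2)cc1)Sc1ccnc2cc(Cl)ccc12` gives 11000 nM
compound 2 `COC(=O)/C(=C\c1ccc(OC(=O)c2cc(OC)cc(OC)c2)cc1)Sc1ccnc2cc(Cl)ccc12` gives 28900 nM
compound 3 `COC(=O)/C(=C\c1ccc(OC(=O)c2c(OC)cccc2OC)cc1)Sc1ccnc2cc(Cl)ccc12` gives 37500 nM

Compound 1 holds the lowest number of the three. Its nearest neighbour is compound 2, reached by a 2.6-fold higher number from compound 1 to compound 2 (0.42 log units; beyond the scatter); the furthest is compound 3, reached by a 3.4-fold higher number from compound 1 to compound 3 (0.53 log units; beyond the scatter). Between compound 2 and compound 3 the step is a 1.3-fold higher number from compound 2 to compound 3 (0.11 log units; within the scatter), so the two dimethoxy variants are not separated.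

Compound 4 `COC(=O)/C(=C\c1ccc(OC(=O)c2ccc(OC)cc2OC)cc1)Sc1ccnc2cc(Cl)ccc12` is not yet measured. Against compound 1 the change is methoxy in place of hydrogen on an aromatic carbon. The two measured steps that bear on this are the ones that turn the 4-methoxyphenyl of compound 1 into a dimethoxyphenyl, compound 1 to compound 2 and compound 1 to compound 3; both raised the number by a modest amount beyond the scatter. Compound 4 keeps the methoxy of compound 1 and adds a second one, so a step of similar kind is expected. For compound 4 the expected step is a 2.0-fold higher number from compound 1 to compound 4 (0.30 log units; within the scatter) in this assay. The estimate for compound 4 is 22000 nM, with a range from 11000 nM to 45000 nM.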

Compound 4, half-maximal inhibitory concentration: 10200 nM
Beside the measured number, compound 4's estimate is 2.2-fold (0.33 log units) above it, outside the stated range (below it).
By their numbers in this assay, from the lowest: compounds 4 and 1 (each within the scatter of the next); then compounds 2 and 3 (each within the scatter of the next).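

In this assay, a methoxy on the aromatic carbon ortho to a large group and meta to a methoxy group does not separate the two compounds: a 1.1-fold lower number from compound 1 to compound 4 (0.03 log units; within the scatter). A second methoxy on this ring is therefore not enough on its own to raise the number, and among these dimethoxy compounds the outcome goes with the arrangement of the two groups: a 3.7-fold lower number from compound 3 to compound 4 (0.57 log units; beyond the scatter), and a 2.8-fold lower number from compound 2 to compound 4 (0.45 log units; beyond the scatter). No measured evidence on why the arrangement matters is at hand.

The compounds shown leave open whether this carbon accepts groups other than methoxy, such as a hydroxyl, an amine or a carboxylic acid, with the same result. They also leave open whether a longer chain, such as ethoxy, would read like methoxy at this carbon.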